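Aryl group on the ring nitrogen of compound 3

A few compounds are considered here, and "the series" means these few. Any claim that something is new, unique, unknown or untested is made for them only; others in the source may bear on it.

Compound 3 `O=C1NC(=S)S/C1=C\N1N=C(c2ccc(Cl)cc2)CC1c1ccc(Cl)cc1` is the parent of this pair. In a functional assay on HL-60 cells (Homo sapiens) for antiproliferative activity, read by MTT assay, with a stated time of 72 h (a higher number here means a weaker inhibitor, a lower number a stronger inhibitor), compound 3 returns only the limit > 10000 nM and no number. Compound 4 `CC(=O)Oc1ccc(N2C(=O)/C(=C/N3N=C(c4ccc(Cl)cc4)CC3c3ccc(Cl)cc3)SC2=S)cc1` is the unmeasured analogue; the change is 4-acetoxyphenyl in place of hydrogen on an amide-type nitrogen in a ring. The nearest measured guide is the pair of compound 1 `CN1C(=O)/C(=C/N2N=C(c3ccccc3)CC2c2ccccc2O)SC1=S` and compound 2 `CCOC(=O)CCN1C(=O)/C(=C/N2N=C(c3ccccc3)CC2c2ccccc2O)SC1=S`. In this assay compound 1 gives 2880 nM. In this assay compound 2 reaches only the limit > 10000 nM, so that step is bounded: an at least 3.4-fold higher number from compound 1 to compound 2 (0.54 log units; beyond the scatter). Both changes replace a hydrogen with a larger group at the amide-type nitrogen in the ring, one directly and one on a saturated chain carbon bound to that nitrogen, though the groups and the cores otherwise differ. Compound 2 and compound 3 both sit at the limit of > 10000 nM in this assay, at which 2 of the 3 values shown sit, so compound 3 offers no numerical footing from which a further loss could be resolved. For the measured compounds named here, with compound 3 already outside the measurable range and the only related step pointing toward weaker inhibition, no gain is expected, and the step from compound 3 to compound 4 is estimated at a step that the limit leaves unreadable from compound 3 to compound 4. Compound 4 is therefore expected at 15000 nM, within 3000 nM to 60000 nM, most likely reported again as a limit.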

Compound 4, half-maximal inhibitory concentration: > 10000 nM
Compound 4 ended at the assay's limit (the forecaster's own chance of this, stated with the estimate: 75%); the middle value does not contradict the limit.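

In this assay compound 4 gives > 10000 nM, a limit and not a number. Compound 3 also stands at a limit, so no step from it to compound 4 can be read: the limit of > 10000 nM in this assay, at which 3 of the 4 values shown sit.

The compounds shown leave open whether 4-acetoxyphenyl in place of hydrogen on the ring's amide-type nitrogen changes the read-out on this core at all.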